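The source may hold more compounds than are shown below. What is called first, only, known or untested is meant among the compounds shown, and "the series" means these compounds.

Measured so far:
compound 1, `O=C1/C(=C2/C(=O)N([C@@H]3O[C@H](CO)[C@@H](O)[C@H](O)[C@H]3O)c3ccccc32)Nc2ccccc21`: 15700 nM
compound 2, `C[C@@H]1O[C@@H](N2C(=O)/C(=C3\Nc4ccccc4C3=O)c3ccccc32)[C@H](O)[C@H](O)[C@H]1O`: 760 nM

Both were tested in a functional assay on MCF7 cells (Homo sapiens) for inhibition; on this read-out lower numbers stand for stronger inhibition and higher numbers for weaker inhibition. Of the two, compound 1 has the highest number, so it is the weaker inhibitor; compound 2 sits a good way lower, well beyond the scatter. Compound 3, `O=C1/C(=C2/C(=O)N([C@@H]3O[C@H](CO)[C@@H](O)[C@H](O)[C@@H]3O)c3ccccc32)Nc2ccccc21`, has not been measured. It differs from compound 1 only in one place: the two compounds have the same atoms and bonds and differ only in configuration as drawn: 1 of 6 stereo elements differ; a stereocentre at a saturated ring carbon is drawn R in compound 1 and S in compound 3. Within the data shown here, because no measured pair shows what such a flip does here, the direction is open; a modest step in either direction, or none beyond the scatter, seems plausible. Compound 3 is expected to give about 9000 nM, likely between 2500 nM and 30000 nM, a step of a 1.7-fold lower number from compound 1 to compound 3 (0.24 log units; within the scatter).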

Compound 3, half-maximal inhibitory concentration: 4220 nM
Compound 3: the middle estimate sits 2.1-fold (0.33 log units) above what was measured; the range from low to high includes it.
By their numbers in this assay, from the lowest: compound 2; then compound 3; then compound 1.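

Turning a stereocentre at a saturated ring carbon from R to S gives a 3.7-fold lower number from compound 1 to compound 3 (0.57 log units; beyond the scatter) in this assay, so the spatial arrangement at this one carbon matters on its own, with no atom added or removed. Nothing else in the structure can account for the step: the fact that compounds 1 and 3 differ only in the configuration as drawn. From the compounds shown here alone, whether the other stereocentres are as sensitive remains open. Also open, going by these compounds, is what an amine or a fluorine at this carbon would do to the inhibition.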